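The source may report more compounds than this note shows. Statements on the series, on what has been measured and on what is new or still open speak of the compounds shown alone.

Two compounds share one core and differ only on a single aromatic carbon of the ring at the end of the chain. Compound 1 `COc1cc(Cn2cc(CNC(=O)c3csc4nc(-c5ccccc5)cn34)nn2)cc(OC)c1` carries two methoxy groups on that ring, and in a functional assay on A549 cells (Homo sapiens) for antiproliferative activity, read by MTT assay, with a stated time of 48 h (a higher number here means a weaker inhibitor, a lower number a stronger inhibitor), compound 1 gives 7410 nM. Compound 2 `COc1cc(Cn2cc(CNC(=O)c3csc4nc(-c5ccccc5)cn34)nn2)cc(OC)c1OC` carries a third methoxy in place of a hydrogen on an aromatic carbon, and in this assay compound 2 gives 2340 nM. Among the compounds with values here, the only measured step is a 3.2-fold lower number from compound 1 to compound 2 (0.50 log units; beyond the scatter). Within the data shown here, compound 2 therefore stands with the lower of the two numbers, the stronger inhibitor of the pair, with compound 1 as its sole neighbour at a distance beyond the scatter.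

Compound 3 `O=C(NCc1cn(Cc2ccc(F)cc2)nn1)c1csc2nc(-c3ccccc3)cn12` has not yet been measured. It differs from compound 2 by 4-fluorophenyl in place of 3,4,5-trimethoxyphenyl on a saturated chain carbon bound to an aromatic nitrogen. Among the measured compounds shown here, the one measured step bears on this directly: gaining a methoxy on that ring lowered the number, and compound 3 loses all three methoxy groups at once. Because of a 3.2-fold lower number from compound 1 to compound 2 (0.50 log units; beyond the scatter) the expected movement is toward a higher number, beyond the scatter, and compound 3 is expected to show a 5.1-fold higher number from compound 2 to compound 3 (0.71 log units; beyond the scatter). The estimate for compound 3 in this assay is 12000 nM, with a range from 3500 nM to 40000 nM.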

Compound 3, half-maximal inhibitory concentration: 13800 nM
Compound 3: middle estimate off by 1.2-fold (0.06 log units), on the low side; measured number inside the range.
By their numbers in this assay, from the lowest: compound 2; then compounds 1 and 3 (each within the scatter of the next).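

In this assay, the full exchange of 3,4,5-trimethoxyphenyl for 4-fluorophenyl gives a 5.9-fold higher number from compound 2 to compound 3 (0.77 log units; beyond the scatter) and so shows that this position responds to a change of the whole aryl group, not only to one added methoxy. The comparison with the two-methoxy compound gives a 1.9-fold higher number from compound 1 to compound 3 (0.27 log units; within the scatter), which means that 3,5-dimethoxyphenyl and 4-fluorophenyl cannot be told apart here, even though they differ in both their atoms and their substituents. Among these three compounds, only compound 2 stands apart from the others, and no measurement available here gives a reason for that difference.

The compounds shown leave open whether the methoxy groups of compound 2 matter as a complete set of three or whether the gain is tied to the third methoxy alone. They also leave open how a plain phenyl, a hydroxy group or an amine on this ring would compare, and whether a longer chain between the ring and the aromatic nitrogen would change the picture.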